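Same Methyl-to-Fluoro Swap, Applied to a Second Pair

A few compounds are considered here, and "the series" means these few. Any claim that something is new, unique, unknown or untested is made for them only; others in the source may bear on it.

Compound 1 `Cc1ccc(S(=O)(=O)N2N=C(c3ccc(N4CCN(C)CC4)cc3)CC2c2ccc(N(C)C)cc2)cc1` gives 10.7% in a functional assay on MDA-MB-231 cells (Homo sapiens) for inhibition, read by sulforhodamine B assay, tested at 10 uM; a higher number here means more inhibition at the concentration tested (going by the name of the read-out), a lower number less inhibition. Compound 2 `CN1CCN(c2ccc(C3=NN(S(=O)(=O)c4ccc(F)cc4)C(c4ccc(N(C)C)cc4)C3)cc2)CC1` differs from it by fluoro in place of methyl on an aromatic carbon, and in this assay compound 2 gives 15.7%, a step of a number 5 percentage points higher from compound 1 to compound 2 (within the scatter). Compound 3 `Cc1ccc(S(=O)(=O)N2N=C(c3ccc(-n4cncn4)cc3)CC2c2ccc(N(C)C)cc2)cc1` differs from compound 1 by 1H-1,2,4-triazol-1-yl in place of 4-methylpiperazin-1-yl on an aromatic carbon; in this assay compound 3 gives 20.7%, so that a number 10 percentage points higher from compound 1 to compound 3 (within the scatter). Compound 4 `CN(C)c1ccc(C2CC(c3ccc(-n4cncn4)cc3)=NN2S(=O)(=O)c2ccc(F)cc2)cc1` has not yet been measured. It differs from compound 3 by fluoro in place of methyl on an aromatic carbon, the same change that turns compound 1 into compound 2, at a place described in the same words. Because a number 5 percentage points higher from compound 1 to compound 2 (within the scatter), the corresponding step of a number 4.3 percentage points higher from compound 3 to compound 4 (within the scatter) is expected to be of similar, small size. Compound 4 is therefore estimated to give about 25%, most likely between 12% and 38%.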

Compound 4, a percentage reported as inhibition, at one concentration (the size of the read-out at that concentration, not a potency): 12.1%
Beside the measured number, compound 4's estimate is 12.9 percentage points above it, within the range that was stated.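

In this assay, carrying the fluoro-for-methyl change onto the second core gives a number 8.6 percentage points lower from compound 3 to compound 4 (within the scatter), and this step does not differ from the earlier one by more than the scatter: the same change on two cores in this assay, a number 5 percentage points higher (within the scatter) from compound 1 to compound 2 and a number 8.6 percentage points lower (within the scatter) from compound 3 to compound 4, 13.6 percentage points apart, within the scatter of two such steps. The change from 4-methylpiperazin-1-yl to 1H-1,2,4-triazol-1-yl, read on the fluoro compounds, gives a number 3.6 percentage points lower from compound 2 to compound 4 (within the scatter) and reads the same way: the same change on two cores in this assay, a number 10 percentage points higher (within the scatter) from compound 1 to compound 3 and a number 3.6 percentage points lower (within the scatter) from compound 2 to compound 4, 13.6 percentage points apart, within the scatter of two such steps. Neither change is thus shown to behave differently on the two cores, but every step lies within the scatter, so the data do not show that either effect carries over.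

Open, going by these compounds, is how a chloro or methoxy group would read in place of the fluoro, or a carboxylic acid in place of the 1H-1,2,4-triazol-1-yl. Also open, on these data alone, is whether a step beyond the scatter would carry from one core to another.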